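Replacing an Aromatic Amide Group with a Butyl Chain

The compounds below may be only part of what the source reports. "The series", "measured", "known", "first", "only" and "open" are said of these compounds alone.

Compound 1 `CN1CCC(c2c[nH]c3ccc(NC(=O)c4cccc(F)c4)nc23)CC1` gives 11 nM in an assay for binding affinity to 5-hydroxytryptamine receptor 1F (Homo sapiens), read by radioligand binding; on this read-out lower numbers stand for stronger inhibition and higher numbers for weaker inhibition.
Compound 2 `CN1CCC(c2c[nH]c3ccc(NC(=O)c4ccc(C#N)cc4)nc23)CC1` gives 7.2 nM in this assay.

Compound 2 stands alongside compound 1: the step of a 1.5-fold lower number from compound 1 to compound 2 (0.18 log units; within the scatter) is within the scatter, so the two cannot be told apart. Compound 3 `CCCCC(=O)Nc1ccc2[nH]cc(C3CCN(C)CC3)c2n1` differs from compound 2 in one place: butyl in place of 4-cyanophenyl on a carbonyl carbon. Within the data shown here, the single measured step exchanges one ring-bearing group for another and is within the scatter; no measured step replaces a ring with a chain. The expectation for compound 3 therefore rests on little, and a modest weakening is estimated, a 2.8-fold higher number from compound 2 to compound 3 (0.44 log units; beyond the scatter). Compound 3 is expected at 20 nM, with a range from 5 nM to 80 nM.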

Compound 3, inhibition constant: 14 nM
Estimate against measurement, compound 3: 1.4-fold (0.15 log units) above, within the range that was stated.
By their numbers in this assay, from the lowest: compounds 2, 1 and 3 (each within the scatter of the next).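

On a carbonyl carbon, an aromatic ring is not required for a low number in this assay: butyl in place of 4-cyanophenyl gives a 1.9-fold higher number from compound 2 to compound 3 (0.29 log units; within the scatter) and butyl in place of 3-fluorophenyl gives a 1.3-fold higher number from compound 1 to compound 3 (0.10 log units; within the scatter), so the three compounds cannot be told apart. A chain with no ring and fewer heavy atoms therefore serves as well here as either ring-bearing group. No evidence is available to explain this result. Still open, as far as these compounds go, is whether a longer chain, a branched chain or a carboxylic acid at this place would hold these numbers.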